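Fluoro in place of hydrogen: compound 2 to compound 3

The compounds below may be only part of what the source reports. "The series", "measured", "known", "first", "only" and "open" are said of these compounds alone.

Of the compounds shown here, two have been measured so far. In a physicochemical assay for lipophilicity, at pH 7.4 (a lower number here means a more polar compound, a higher number a more lipophilic compound), compound 1 `CNC(=O)N(c1ccc(S(=O)(=O)Nc2ccon2)cn1)c1cc(Cl)c(-c2ccc(F)c(OCC(F)(F)F)c2)cc1OC` gives 0.9 and compound 2 `CNC(=O)N(c1ccc(S(=O)(=O)Nc2ncccn2)cn1)c1cc(F)c(-c2cccc(C(F)(F)F)c2)cc1OC` gives 1. Among the compounds with values here, these two values lie within the scatter of each other, so compound 2 stands level with the only other measured number.

Compound 3 `CNC(=O)N(c1ccc(S(=O)(=O)Nc2ncccn2)cn1)c1cc(F)c(-c2ccc(F)c(C(F)(F)F)c2)cc1OC` is the next to be read in this assay. It differs from compound 2 by fluoro in place of hydrogen on an aromatic carbon. This is fluoro in place of hydrogen on an aromatic carbon, ortho to a trifluoromethyl group and para to a large group, and it turns 3-(trifluoromethyl)phenyl into 4-fluoro-3-(trifluoromethyl)phenyl.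

Within the data shown here, no pair of measured compounds differs in one place only, and the series therefore offers no direct measure of this change. The expectation rests on the small size of the structural change alone. The estimated step of a number 0.15 log units higher from compound 2 to compound 3 (within the scatter) is small and upward, and it is not expected to clear the scatter. For compound 3 the estimate is 1.15, with an expected range of 0.8 to 1.5.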

Compound 3, distribution coefficient: 1.2
The estimate for compound 3 lay 0.05 log units below the measured number; the range from low to high includes it.
By their numbers in this assay, from the lowest: compounds 1, 2 and 3 (each within the scatter of the next).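

In this assay, the series now has its first comparison of compounds that differ in one place: a number 0.20 log units higher from compound 2 to compound 3 (within the scatter), for fluoro in place of hydrogen on an aromatic carbon, ortho to a trifluoromethyl group and para to a large group. At this position, the change from 3-(trifluoromethyl)phenyl to 4-fluoro-3-(trifluoromethyl)phenyl does not separate the two compounds beyond the usual scatter, so this single fluoro exchange gives no clear shift in the distribution coefficient. Nothing available bears on the reason for this result.

From the compounds shown here alone, whether a different group on this same aromatic carbon, such as an amine or a carboxylic acid, would give a step beyond the scatter remains open. Within the data shown here, with only this one step available, it is also open whether fluoro in place of hydrogen would give a similar step on another aromatic carbon, or on this carbon without the trifluoromethyl group ortho to it.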